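Series notes: methoxy in place of chloro on the shared core

The compounds below may be only part of what the source reports. "The series", "measured", "known", "first", "only" and "open" are said of these compounds alone.

Measured compounds in an assay on isolated protein for inhibition of Amine oxidase [flavin-containing] A (Homo sapiens), read by fluorescence, with a stated time of 15 min; a lower number here means a stronger inhibitor, a higher number a weaker inhibitor:
compound 1 `COc1ccc(/C=C/c2cc(OC)cc(OC)c2/C=C/C(=O)c2cc3ccc(Br)cc3oc2=O)cc1` — 3010 nM
compound 2 `COc1ccc(/C=C/c2cc(OC)cc(OC)c2/C=C/C(=O)c2cc3ccc(Cl)cc3oc2=O)cc1` — > 60000 nM

Compound 2 gives only a limit, > 60000 nM, not a number; it sits at the limit of > 60000 nM in this assay, at which 1 of the 2 values shown sits. Among the measured compounds shown here, compound 1, the single other member, gives 3010 nM. For the measured compounds named here, the one measured step, an at least 19-fold higher number from compound 1 to compound 2 (1.29 log units; beyond the scatter), is large, so compound 2 stands at the weak end of what has been seen in this assay, with its true value unknown beyond the limit.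

Compound 3 `COc1ccc(/C=C/c2cc(OC)cc(OC)c2/C=C/C(=O)c2cc3ccc(OC)cc3oc2=O)cc1` is to be measured. It differs from compound 2 by methoxy in place of chloro on an aromatic carbon. Going by the values given here, no measured step exchanges chloro for methoxy, so nothing bears directly on it; the step from compound 1 to compound 2 only shows that a change at this position can move the number well beyond the scatter. The direction for compound 3 is therefore open. Compound 3 is expected to give 30000 nM (range 5000 nM to 100000 nM), which would be a step of an at least 2.0-fold lower number from compound 2 to compound 3 (0.30 log units; that floor lies within the scatter) and is estimated with wide uncertainty.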

Compound 3, half-maximal inhibitory concentration: > 60000 nM
Compound 3 ended at the assay's limit; the forecaster's own chance of this, stated with the estimate: 50%; at least 2.0-fold (0.30 log units) between middle value and limit.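

In this assay compound 3 gives > 60000 nM, which is a limit of the assay and not a number. Methoxy in place of bromo on this aromatic carbon gives an at least 19-fold higher number from compound 1 to compound 3 (1.29 log units; beyond the scatter), so a second, different replacement of bromo also takes the series out of the readable range, and the large change seen with chloro is no longer a single case. The step between compound 2 and compound 3 cannot be read, so chloro and methoxy cannot be ordered against each other, and compound 1 stays the only one of the three with a measured number, since the other two both end at the same limit: the limit of > 60000 nM in this assay, at which 2 of the 3 values shown sit.

How far compound 2 and compound 3 lie past that limit remains unknown, and with only three groups shown at this place, the bromo result cannot yet be called a trend. Iodo, methyl or an amine on the same aromatic carbon would show whether bromo stands alone in giving a readable number on the shared core.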